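A few compounds are considered here, and "the series" means these few. Any claim that something is new, unique, unknown or untested is made for them only; others in the source may bear on it.

Within the data shown here, compound 1 `COc1cc(C2=NN(C(C)=O)C(c3c(Cl)cccc3Cl)O2)cc(OC)c1OC` is the weaker of the two compounds measured so far: in a functional assay on BGC-823 cells (Homo sapiens) for antiproliferative activity, read by MTT assay, tested at 5 uM (a higher number here means a stronger effect of the compound at the concentration tested, a lower number a weaker effect), compound 1 gives 15.9%. Compound 2 `COc1cc(C(=O)N/N=C/c2cccc(C(F)(F)F)c2)cc(OC)c1OC` reaches 33.8% in this assay, a gap beyond the usual scatter of such measurements. Compound 3 `COc1cc(C2=NN(C(C)=O)C(c3ccc(F)c(F)c3)O2)cc(OC)c1OC` has not yet been measured; it differs from compound 1 in a single place: 3,4-difluorophenyl in place of 2,6-dichlorophenyl on a saturated ring carbon. Among the measured compounds shown here, no measured pair shows how this kind of exchange plays out, so the step of a number 2.1 percentage points higher from compound 1 to compound 3 (within the scatter) is expected to stay within the scatter, with no clear direction. Compound 3 is therefore estimated at 18% in this assay, in a range from 5% to 35%.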

Compound 3, a percentage reported as inhibition, at one concentration (the size of the read-out at that concentration, not a potency): 21.6%
Compound 3: middle estimate off by 3.6 percentage points, on the low side; measured number inside the range.
By their numbers in this assay, from the lowest: compounds 1 and 3 (each within the scatter of the next); then compound 2.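

In this assay, putting 3,4-difluorophenyl in place of 2,6-dichlorophenyl on the saturated ring carbon gives a number 5.7 percentage points higher from compound 1 to compound 3 (within the scatter). Among these compounds, this is the first direct reading at this position: this exchange of one halogen-bearing phenyl for another does not separate compound 1 from compound 3. No measurement at hand gives a reason for this result. Going by these compounds, because both halogen and substitution pattern change together, their separate contributions remain open. Also open, on these data alone, is whether a phenyl carrying an amine or a carboxylic acid on this carbon would give a step beyond the scatter.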